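Trimming the alkynyl chain of compound 2 to a bare ethynyl

The source may hold more compounds than are shown below. What is called first, only, known or untested is meant among the compounds shown, and "the series" means these compounds.

Measured compounds:
compound 1 `CCCC#Cc1cn([C@@H]2O[C@H](CO)[C@@H](O)[C@H](O)[C@H]2O)c(=O)[nH]c1=O` – 123000 nM
compound 2 `CCCCCC#Cc1cn([C@@H]2O[C@H](CO)[C@@H](O)[C@H](O)[C@H]2O)c(=O)nc1N` – > 250000 nM
compound 3 `CCCCCc1ccc(C#Cc2cn([C@@H]3O[C@H](CO)[C@@H](O)[C@H](O)[C@H]3O)c(=O)nc2O)cc1` – 81000 nM

All three were tested in a functional assay on CCRF-CEM cells (Homo sapiens) for cytotoxicity, with a stated time of 72 h; on this read-out lower numbers stand for stronger inhibition and higher numbers for weaker inhibition. Compound 1 gives 123000 nM. Compound 3 gives 81000 nM. For compound 2 the reading is only a limit of the assay, > 250000 nM, so no number is known for it; this is the situation described by the limit of > 250000 nM in this assay, at which 1 of the 3 values shown sits, and compound 2 therefore stands at the weak end of what was recorded.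

Compound 4 `C#Cc1cn([C@@H]2O[C@H](CO)[C@@H](O)[C@H](O)[C@H]2O)c(=O)nc1N` has not yet been tested. It differs from compound 2 in one place: hydrogen in place of pentyl on a triple-bonded carbon. For the measured compounds named here, no measured pair shows this change, and none of the measured values is a firm number on the side of compound 2, so the direction of the step in this assay cannot be read off the data. The expectation is a step of an at least 1.2-fold lower number from compound 2 to compound 4 (0.09 log units; that floor lies within the scatter), that is, little or no movement beyond the scatter, since all three measured compounds sit far from strong inhibition. Compound 4 is accordingly estimated at 200000 nM, within 50000 nM to 400000 nM, with a fair chance that only a limit is reported again.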

Compound 4, half-maximal inhibitory concentration: > 250000 nM
Compound 4: a limit, no number; the forecaster's own chance of this, stated with the estimate: 55%; middle value at least 1.2-fold (0.09 log units) from the limit.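

Compound 2 and compound 4 both end at a limit of the assay rather than a number, so the step between them cannot be read: the limit of > 250000 nM in this assay, at which 2 of the 4 values shown sit. The compounds shown leave open whether hydrogen in place of pentyl on a triple-bonded carbon changes the cytotoxicity at all.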